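A few compounds are considered here, and "the series" means these few. Any claim that something is new, unique, unknown or untested is made for them only; others in the source may bear on it.

Measured so far in an assay on HEK293 cells for displacement of a labelled ligand from C-X-C chemokine receptor type 3 (Homo sapiens); a higher number here means a weaker inhibitor, a lower number a stronger inhibitor:
- compound 1, `CN(CC1=CC[C@H]2C[C@@H]1C2(C)C)Cc1ccc(Br)cc1`: 3160 nM
- compound 2, `CN(CC1=CC[C@H]2C[C@@H]1C2(C)C)Cc1ccc(-c2cccc(F)c2)cc1`: 2510 nM

Among the compounds with values here, compound 2 holds the lower of the two numbers, with compound 1 its only neighbour; the step of a 1.3-fold lower number from compound 1 to compound 2 (0.10 log units; within the scatter) sits within the scatter, so the two compounds cannot be ordered against each other on this evidence.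

Compound 3, `Cc1cccc(-c2ccc(CN(C)CC3=CC[C@H]4C[C@@H]3C4(C)C)cc2)c1`, is reached from compound 2 by a single change: methyl in place of fluoro on an aromatic carbon, on an aromatic carbon of a six-membered aromatic ring of carbon only. The change is a swap of one single-atom substituent for another on the outer ring, without any change in ring count, donors, acceptors or charge.

Within the data shown here, only one measured step exists, and it touches the same region: a 1.3-fold lower number from compound 1 to compound 2 (0.10 log units; within the scatter), which replaced bromo by the whole 3-fluorophenyl group and still stayed within the scatter. Among the measured compounds shown here, no measured pair swaps fluoro for methyl, so there is no direct precedent. Given that a far larger change at this position left the number unmoved beyond the scatter, a single-atom swap is expected to do the same.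

The step from compound 2 to compound 3 is therefore expected as a 1.0-fold lower number from compound 2 to compound 3 (0.00 log units; within the scatter), no more than the scatter. Compound 3 is estimated at 2500 nM, between 1000 nM and 6300 nM.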

Compound 3, inhibition constant: > 316 nM
Compound 3 ended at the assay's limit; the forecaster's own chance of this, stated with the estimate: 5%; the middle value is on the limit's open side.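

In this assay compound 3 gives > 316 nM which is a limit of the assay and not a number. The steps to compound 3 from compound 1 and compound 2 therefore cannot be read: the limit of > 316 nM in this assay, at which 1 of the 3 values shown sits.

Left open is how compound 3, with its 3-methylphenyl group, stands against compound 2, with its 3-fluorophenyl group.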